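Chloro Added at the Benzylsulfanyl Arm of Compound 3

This account rests on a few compounds, and the source may have more. Where it says the series, first, only, none or still open, it means among the compounds named here.

Measured compounds:
compound 1 `COc1ccc(C2N=C(SCc3cccc(Cl)c3)NC(C)=C2C(=O)Nc2ccc(F)cc2)cc1OC` — 2.1%
compound 2 `COc1ccc(C2N=C(SCc3ccc(F)cc3)NC(C)=C2C(=O)Nc2ccc(F)cc2)cc1OC` — 3.6%
compound 3 `CC1=C(C(=O)Nc2ccc(Br)cc2)C(c2ccc(Cl)cc2Cl)N=C(SCc2ccccc2)N1` — 1.5%

In a functional assay on the whole organism (artery, strain albino) with Rattus norvegicus as the target, with a stated time of 15 min, at a dose of 10 mg/kg by the oral route (on this read-out lower numbers stand for less inhibition and higher numbers for more inhibition at the one dose given (going by the name of the read-out)), compound 3 gives 1.5%. Compound 1 gives 2.1% and compound 2 gives 3.6%, and all three numbers stand within the scatter of one another, so none of the three can be told apart on this read-out. Compound 4 `CC1=C(C(=O)Nc2ccc(Br)cc2)C(c2ccc(Cl)cc2Cl)N=C(SCc2ccccc2Cl)N1` has not yet been measured. It differs from compound 3 by chloro in place of hydrogen on an aromatic carbon. For the measured compounds named here, the only measured step that touches the same part of the molecule, the benzylsulfanyl group, is a number 1.5 percentage points higher from compound 1 to compound 2 (within the scatter), a step that stayed within the scatter. Going by the values given here, nothing measured here separates a chloro on that ring from a hydrogen, and every number so far sits near the bottom of the read-out. For compound 4 the account therefore expects no step beyond the scatter in this assay, that is a number 1 percentage points higher from compound 3 to compound 4 (within the scatter). Compound 4 is expected to give 2.5%, with a range from -5% to 12%.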

Compound 4, a percentage reported as inhibition, in the whole organism at one dose (the size of the read-out at that dose, not a potency): 3.1%
Compound 4: middle estimate off by 0.6 percentage points, on the low side, within the range that was stated.
By their numbers in this assay, from the lowest: compounds 3, 1, 4 and 2 (each within the scatter of the next).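

In this assay, the change from benzylsulfanyl to (2-chlorobenzyl)sulfanyl gives a number 1.6 percentage points higher from compound 3 to compound 4 (within the scatter), so chloro in place of hydrogen at this place, ortho to a large group, cannot be told from hydrogen on this read-out. The earlier step on this arm exchanged one halogen-bearing phenyl group for another, whereas this step adds chloro to a phenyl ring that carried no substituent, and it too stays within the scatter. No measurement here bears on why the read-out stays flat at this position.

The compounds shown leave open whether an amine or a carboxylic acid at this ring carbon, or a longer chain in place of the benzyl group, would move the read-out beyond the scatter. They also leave open whether 2-chlorobenzyl would give the same result on the core of compound 1.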